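This account rests on a few compounds, and the source may have more. Where it says the series, first, only, none or still open, it means among the compounds named here.

Measured so far:
- compound 1, `CC1=C(C(=O)CC(C)C)C(c2ccsc2)NC(=O)N1`: 1000 nM in an assay on membranes from HEK293 cells for displacement of a labelled ligand from adenosine receptor A2b (Homo sapiens), read by scintillation counting, with a stated time of 30 min; on this read-out higher numbers stand for weaker inhibition and lower numbers for stronger inhibition
- compound 2, `CC1=C(c2ncc(C)o2)C(c2ccco2)NC(=O)N1`: 905 nM in this assay

Both values come from the same binding measurement, and the two numbers lie so close together that nothing separates them: the gap between compound 1 and compound 2 is within the usual scatter of repeated measurements, so neither can be called the stronger binder on this evidence. Compound 2 simply stands at one end of a pair whose numbers are, for practical purposes, the same.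

Compound 3, `CC1=C(c2ncc(C)o2)C(c2ccsc2)NC(=O)N1`, has not yet been measured. It keeps the shared core of compound 2 together with the 5-methyl-1,3-oxazol-2-yl group, and differs only in one place: thiophen-3-yl in place of furan-2-yl on a saturated ring carbon. The aromatic ring that enters is the same one that compound 1 carries at this position, while compound 1 differs from compound 2 elsewhere, so no clean single-change comparison is available for this swap. Within the data shown here, with two measured compounds only, and no isolated step to lean on, the expectation is of a small step, if any, in either direction, with nothing beyond the scatter foreseen. Compound 3 is therefore expected to give about 800 nM, with a plausible range from 300 nM to 2500 nM; the expected step from compound 2 to compound 3 is a 1.1-fold lower number from compound 2 to compound 3 (0.05 log units; within the scatter).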

Compound 3, inhibition constant: 1130 nM
Beside the measured number, compound 3's estimate is 1.4-fold (0.15 log units) below it, within the range that was stated.
By their numbers in this assay, from the lowest: compounds 2, 1 and 3 (each within the scatter of the next).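

Among these compounds, replacing furan-2-yl with thiophen-3-yl on the saturated ring carbon in this assay gives the first clean single-change comparison at this position (a 1.2-fold higher number from compound 2 to compound 3 (0.10 log units; within the scatter)), and the two rings, one containing oxygen and the other sulfur, cannot be told apart on this read-out. The second comparison keeps thiophen-3-yl fixed and places 5-methyl-1,3-oxazol-2-yl in place of isobutylcarbonyl on the double-bonded ring carbon (a 1.1-fold higher number from compound 1 to compound 3 (0.05 log units; within the scatter)), so these two quite different groups cannot be told apart here either. No other measurement bears on these results, so the numbers alone cannot explain why neither change separates the compounds.

Going by these compounds, the effect of a phenyl ring or a simple amine on the saturated ring carbon remains open, as does whether furan-2-yl and thiophen-3-yl would still match with isobutylcarbonyl on the double-bonded ring carbon. Among the compounds shown here, every step so far lies within the scatter, and whether any change at either place can move the number beyond it also remains open.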